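A few compounds are considered here, and "the series" means these few. Any claim that something is new, unique, unknown or untested is made for them only; others in the source may bear on it.

Compound 1 `CCCS(=O)(=O)Nc1ccc(F)c(NC(=O)Nc2ncnc3[nH]ncc23)c1F` is a urea that links a fluorinated, sulfonamide-bearing aryl group to a fused two-ring core. In a physicochemical assay for solubility, using the shake flask method, measured as thermodynamic solubility, with a stated time of 24 h, at pH 1.2, tested at 0.5 mg/mL (a lower number here means a less soluble compound, a higher number a more soluble compound), compound 1 gives 7 ug/mL, the lowest of the two numbers recorded so far. Going by the values given here, its only measured neighbour is compound 2 `CCCS(=O)(=O)Nc1ccc(F)c(NC(=O)Nc2cc(NC)ncn2)c1F`, in which the fused core is replaced by a single six-membered ring carrying a methylamino group; in this assay compound 2 gives 900 ug/mL, and the step of a 130-fold higher number from compound 1 to compound 2 (2.11 log units; beyond the scatter) is the one large move available. Compound 3 `CCCS(=O)(=O)Nc1ccc(F)c(NC(=O)Nc2ncnc3[nH]nc(OC)c23)c1F` keeps the fused core of compound 1 and alters it in one place: methoxy in place of hydrogen on an aromatic carbon. Among the compounds with values here, no measured step bears directly on this change: the step from compound 1 to compound 2 exchanges the whole ring system, whereas compound 3 adds a methoxy to a core that is otherwise unchanged. With nothing to push the number in either direction, for compound 3 the expected move is a 1.4-fold higher number from compound 1 to compound 3 (0.15 log units; within the scatter), one that need not exceed the scatter. In this assay compound 3 is therefore estimated at 10 ug/mL, within a range from 3 ug/mL to 35 ug/mL.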

Compound 3, solubility: 49 ug/mL
For compound 3 the middle estimate is 4.9-fold (0.69 log units) below the measured one; measured number above the stated range.
By their numbers in this assay, from the lowest: compound 1; then compound 3; then compound 2.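

On the core of compound 1, methoxy in place of hydrogen on an aromatic carbon of the five-membered aromatic ring, next to the ring nitrogen, moves the number in this assay, with a 7.0-fold higher number from compound 1 to compound 3 (0.85 log units; beyond the scatter) as the step. The earlier step exchanged the whole ring system, whereas this one keeps the core and changes a single position, showing that methoxy at this position is enough to take the reading beyond the scatter. The step remains modest beside a 130-fold higher number from compound 1 to compound 2 (2.11 log units; beyond the scatter), so compound 3 ranks between the other two, and nothing at hand accounts for the change at this position.

From the compounds shown here alone, whether this rise belongs to methoxy itself or would also come with another group at this position, such as an amine, a hydroxyl or a longer ethoxy chain, stays open. Going by these compounds alone, also open is whether methoxy would have a similar effect on the single six-membered ring of compound 2, which carries a methylamino group and already gives a far higher number.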